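Swapping one end group on compound 2

The source may hold more compounds than are shown below. What is called first, only, known or untested is meant among the compounds shown, and "the series" means these compounds.

Two compounds have been measured in a physicochemical assay for lipophilicity; a lower number here means a more polar compound, a higher number a more lipophilic compound:

Compound 1 `Cc1cn(C2CC(N=[N+]=[N-])C(COC(=O)NCCCC(=O)OC(C)(C)C)O2)c(=O)[nH]c1=O` gives 0.88
Compound 2 `Cc1cn(C2CC(N=[N+]=[N-])C(COC(=O)OCCCCO)O2)c(=O)[nH]c1=O` gives -0.68

Compound 2 stands at -0.68 and is the lower of the two, while compound 1 sits above it by more than the usual scatter. Compound 3 `Cc1cn(C2CC(N=[N+]=[N-])C(COC(=O)NCCCC(=O)O)O2)c(=O)[nH]c1=O` keeps the shared core of compound 2 but changes one end of the molecule: (3-carboxypropyl)amino in place of 4-hydroxybutoxy on a carbonyl carbon. Going by the values given here, no two measured compounds differ in only one place, so no measured step shows what this swap does. A small downward move is expected, and the estimated a number 0.12 log units lower from compound 2 to compound 3 (within the scatter) would stay within the scatter. The range is kept wide, as nothing measured supports it directly. In this assay the estimate for compound 3 is -0.8 (range -1.6 to -0.1).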

Compound 3, partition coefficient: -0.81
Compound 3: the middle estimate sits 0.01 log units above what was measured; the measured number falls inside the stated range.
By their numbers in this assay, from the lowest: compounds 3 and 2 (each within the scatter of the next); then compound 1.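

In this assay, putting (3-carboxypropyl)amino in place of 4-hydroxybutoxy on this carbonyl carbon gives a number 0.13 log units lower from compound 2 to compound 3 (within the scatter) and so does not separate the two end groups, although the entering group carries a nitrogen that the leaving group lacks. By contrast, hydrogen in place of tert-butyl on an oxygen next to a carbonyl group gives a number 1.69 log units lower from compound 1 to compound 3 (beyond the scatter) in the same assay, so this single change moves the number far more than the end-group swap does. Nothing measured here explains the size of either step.

The compounds shown leave open whether the swap would stay this small with a shorter chain in the entering group. They also leave open what an amine or a methyl ester in place of the carboxylic acid would give.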